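Carboxyl for sulfo at the chain end of a lipopeptide

A few compounds are considered here, and "the series" means these few. Any claim that something is new, unique, unknown or untested is made for them only; others in the source may bear on it.

Two lipopeptides sharing a common core have been measured in an assay on HEK293 cells for agonist activity at Toll-like receptor 2 (Homo sapiens); a higher number here means that more compound is needed for the effect, a lower number that less compound is needed. Compound 1 `CCCCCCCCCCCC(=O)OC[C@H](CSC[C@@H](N)C(=O)NCCCC(C)(C)CO)OC(=O)CCCCCCCCCCC` gives 30700 nM there, while compound 2 `CCCCCCCCCCCC(=O)OC[C@H](CSC[C@@H](N)C(=O)NCCCS(=O)(=O)O)OC(=O)CCCCCCCCCCC` gives 5560 nM. For the measured compounds named here, compound 2 therefore holds the lowest number of the two, and the only measured step, a 5.5-fold lower number from compound 1 to compound 2 (0.74 log units; beyond the scatter), separates it from compound 1.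

Compound 3 `CCCCCCCCCCCC(=O)OC[C@H](CSC[C@@H](N)C(=O)NCCCCCC(=O)O)OC(=O)CCCCCCCCCCC` has not yet been measured. It differs from compound 2 by 2-carboxyethyl in place of sulfo on a saturated chain carbon, three bonds along the chain from an amide-type nitrogen. Going by the values given here, no measured pair shows this exact exchange. Among the compounds with values here, the one step that bears on the place in question is a 5.5-fold lower number from compound 1 to compound 2 (0.74 log units; beyond the scatter), which exchanged a neutral group for sulfo and moved the number beyond the scatter. The new group again carries one hydrogen-bond donor, but it is not sulfo, so compound 3 is expected to sit between the two measured compounds rather than at either end; the step of a 2.0-fold higher number from compound 2 to compound 3 (0.30 log units; within the scatter) is the estimate that follows. For compound 3 the expected value in this assay is 11000 nM, with a range from 3500 nM to 35000 nM.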

Compound 3, half-maximal effective concentration: 108 nM
For compound 3 the middle estimate is 100-fold (2.01 log units) above the measured one, and the stated range ends above it.
By their numbers in this assay, from the lowest: compound 3; then compound 2; then compound 1.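

For the compounds shown here, at this position, on a saturated chain carbon, three bonds along the chain from an amide-type nitrogen, the earlier compounds showed only that sulfo outdid 1-(hydroxymethyl)-1-methylethyl in this assay; now 2-carboxyethyl in place of sulfo brings a 51-fold lower number from compound 2 to compound 3 (1.71 log units; beyond the scatter), so sulfo is not the best end group seen here. Measured against the starting group, 2-carboxyethyl gives a 280-fold lower number from compound 1 to compound 3 (2.45 log units; beyond the scatter), a much larger move than the earlier 5.5-fold lower number from compound 1 to compound 2 (0.74 log units; beyond the scatter), which shows that this position can shift the number far more than the first pair revealed and places compound 3 lowest of the three, with all its steps beyond the scatter. No supporting measurement accompanies these numbers that would explain the size of the step.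

The exchange can equally be read as 3-sulfopropyl to 5-carboxypentyl, so the compounds shown leave open whether the step follows the carboxylic acid or the longer chain, and a sulfo group on the longer chain or a carboxylic acid on a shorter one would separate the two. From the compounds shown here alone, how an amine at the chain end, or an ester of the carboxylic acid, would compare in this assay also remains open.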